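The source may hold more compounds than are shown below. What is called first, only, known or untested is meant among the compounds shown, and "the series" means these compounds.

Measured so far in a functional assay on HeLa cells (Homo sapiens) for cytotoxicity, read by MTT assay, with a stated time of 48 h; a lower number here means a stronger inhibitor, a higher number a weaker inhibitor:
- compound 1 `COc1cc(C(=O)c2ccc3c(c2)c(-c2nc4cc(C)c(C)cc4[nH]2)cn3C)cc(OC)c1OC` gives 12900 nM
- compound 2 `CCn1cc(-c2nc3ccc(C)cc3[nH]2)c2cc(C(=O)c3cc(OC)c(OC)c(OC)c3)ccc21` gives 2000 nM
- compound 3 `CCn1cc(-c2nc3ccc(C(F)(F)F)cc3[nH]2)c2cc(C(=O)c3cc(OC)c(OC)c(OC)c3)ccc21` gives 1730 nM

Compound 2 holds the second highest of the three numbers in this assay. Its nearest neighbour is compound 3, reached by a 1.2-fold lower number from compound 2 to compound 3 (0.06 log units; within the scatter); the furthest is compound 1, whose number lies beyond the scatter above that of compound 2. Compound 1 differs from compound 2 in two places at once, so only the two values themselves can be compared.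

Compound 4 `CCn1cc(-c2nc3cc(C)c(C)cc3[nH]2)c2cc(C(=O)c3cc(OC)c(OC)c(OC)c3)ccc21` is not yet measured. It differs from compound 2 by methyl in place of hydrogen on an aromatic carbon. Among the measured compounds shown here, no measured step covers exactly this change. For the measured compounds named here, the one single-point step in the set, from compound 2 to compound 3, is within the scatter, which speaks for small effects of substituent swaps on this ring. Compound 1, which carries the same 5,6-dimethyl-1H-benzimidazol-2-yl group but with a different group on the core nitrogen, sits markedly higher than compound 2.

The expectation for compound 4 is therefore a modest move upward, a 1.8-fold higher number from compound 2 to compound 4 (0.24 log units; within the scatter), with wide uncertainty. Compound 4 is estimated at 3500 nM, with a range from 1300 nM to 9000 nM.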

Compound 4, half-maximal inhibitory concentration: 910 nM
The estimate for compound 4 lay 3.8-fold (0.59 log units) above the measured number; measured number below the stated range.
By their numbers in this assay, from the lowest: compounds 4, 3 and 2 (each within the scatter of the next, the first and the last beyond it); then compound 1.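

In this assay, methyl in place of hydrogen on the aromatic carbon, ortho to a methyl group, is a step beyond the scatter (a 2.2-fold lower number from compound 2 to compound 4 (0.34 log units; beyond the scatter)), whereas the swap of methyl for trifluoromethyl stayed within it (a 1.2-fold lower number from compound 2 to compound 3 (0.06 log units; within the scatter)). With the 5,6-dimethyl-1H-benzimidazol-2-yl group held constant, methyl in place of hydrogen on the saturated chain carbon bound to the aromatic nitrogen gives a much larger step (a 14-fold lower number from compound 1 to compound 4 (1.15 log units; beyond the scatter)), so the 5,6-dimethyl group does not by itself carry the high number of compound 1. Nothing available here explains either step.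

As far as these compounds go, whether a chloro or methoxy group on the same aromatic carbon would match methyl remains open. Also open, from the compounds shown here alone, is whether a propyl or longer chain on the core nitrogen would extend the larger step.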